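A Ring Closes: Dimethylamino to Pyrrolidin-1-yl

The source may report more compounds than this note shows. Statements on the series, on what has been measured and on what is new or still open speak of the compounds shown alone.

Compound 1 `COc1cc(OC)c(C(=O)/C=C/c2ccccc2Cl)c(O)c1CN1CCCCC1` gives 3100 nM in a functional assay on Bel-7402 cells (Homo sapiens) for antiproliferative activity, with a stated time of 72 h; a higher number here means a weaker inhibitor, a lower number a stronger inhibitor.
Compound 2 `COc1cc(OC)c(C(=O)/C=C/c2ccccc2Cl)c(O)c1CN(C)C` gives 21800 nM in this assay.

Within the data shown here, compound 2 stands at the highest number of the two measured, and its only neighbour is compound 1, reached by the change a 7.0-fold higher number from compound 1 to compound 2 (0.85 log units; beyond the scatter). That single step is the whole of what the data say about substituents on a saturated chain carbon bound to an aromatic carbon: opening the piperidin-1-yl ring into dimethylamino cost a modest but clear amount in this assay.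

Compound 3 `COc1cc(OC)c(C(=O)/C=C/c2ccccc2Cl)c(O)c1CN1CCCC1` is the next member of the series. The difference from compound 2 is pyrrolidin-1-yl in place of dimethylamino on a saturated chain carbon bound to an aromatic carbon. Compound 3 thus carries a ring again, though one member smaller than the ring of compound 1. Because the step of a 7.0-fold higher number from compound 1 to compound 2 (0.85 log units; beyond the scatter) ran toward a higher number when the ring was lost, restoring a ring is expected to move the number back down, though the five-membered ring is not the same as the six-membered one, so a full return is not assumed.

Compound 3 is therefore expected to give 7000 nM in this assay, within 2500 nM to 20000 nM.

That estimate amounts to an expected step of a 3.1-fold lower number from compound 2 to compound 3 (0.49 log units; beyond the scatter).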

Compound 3, half-maximal inhibitory concentration: 6800 nM
Compound 3: the middle estimate sits 1.0-fold (0.01 log units) above what was measured, and the stated range covers the measured number.
By their numbers in this assay, from the lowest: compound 1; then compound 3; then compound 2.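

In this assay the closure of dimethylamino into pyrrolidin-1-yl on a saturated chain carbon bound to an aromatic carbon gives a 3.2-fold lower number from compound 2 to compound 3 (0.51 log units; beyond the scatter), so the gain seen with a ring at this place is not confined to piperidin-1-yl. The two rings are still not interchangeable: the step to the smaller ring is a 2.2-fold higher number from compound 1 to compound 3 (0.34 log units; beyond the scatter), which places compound 3 between the other two and leaves compound 1 as the strongest inhibitor of the three, with its steps to both others beyond the scatter. The order of the three amines is therefore set by more than the mere presence of a ring, but nothing available gives a reason for these differences.

The compounds shown leave open whether an open-chain amine with longer arms, such as diethylamino, would stay close to dimethylamino or move toward the rings. They also leave open whether the trend from pyrrolidin-1-yl to piperidin-1-yl continues to a seven-membered azepan-1-yl ring, or survives a second hetero atom in the ring, as in morpholin-4-yl or 4-methylpiperazin-1-yl.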